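Replacing 3-methylbenzyl with cyclohexyl: working notes

This account rests on a few compounds, and the source may have more. Where it says the series, first, only, none or still open, it means among the compounds named here.

Measured in a functional assay on RAW264.7 cells (Mus musculus) for inhibition, read by Griess assay, with stated times of 2 h and 24 h; on this read-out lower numbers stand for stronger inhibition and higher numbers for weaker inhibition:
compound 1 `COc1ccc([C@@H]2CC(=O)c3c(O)cc(OCc4cn(Cc5ccccc5Cl)nn4)cc3O2)cc1O`: 6140 nM
compound 2 `COc1ccc([C@@H]2CC(=O)c3c(O)cc(OCc4cn(Cc5cccc(C#N)c5)nn4)cc3O2)cc1O`: 18000 nM
compound 3 `COc1ccc([C@@H]2CC(=O)c3c(O)cc(OCc4cn(Cc5cccc(C)c5)nn4)cc3O2)cc1O`: 17400 nM

Two of these numbers do not separate: a 1.0-fold lower number from compound 2 to compound 3 (0.01 log units; within the scatter). That places compound 3 in the higher pair, clear of the lowest number, held by compound 1. The two steps away from that lowest number are modest: a 2.9-fold higher number from compound 1 to compound 2 (0.47 log units; beyond the scatter) and a 2.8-fold higher number from compound 1 to compound 3 (0.45 log units; beyond the scatter).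

The next structure, compound 4 `COc1ccc([C@@H]2CC(=O)c3c(O)cc(OCc4cn(C5CCCCC5)nn4)cc3O2)cc1O`, carries cyclohexyl in place of 3-methylbenzyl on an aromatic nitrogen. Among the compounds with values here, all three measured compounds keep a substituted benzyl group at this place, so no measured step covers its replacement and those steps bear on the change only loosely. They offer no direction, and they suggest a modest size at most. The central expectation in this assay is therefore no change beyond the scatter, with a wide range on either side.

The expected step is a 1.2-fold lower number from compound 3 to compound 4 (0.06 log units; within the scatter). For compound 4 the estimated value is 15000 nM, with an expected range of 6000 nM to 40000 nM.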

Compound 4, half-maximal inhibitory concentration: 15600 nM
For compound 4 the middle estimate is 1.0-fold (0.02 log units) below the measured one; measured number inside the range.
By their numbers in this assay, from the lowest: compound 1; then compounds 4, 3 and 2 (each within the scatter of the next).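

Cyclohexyl is the first group on this aromatic nitrogen that is not a substituted benzyl, and it does not separate from 3-methylbenzyl or 3-cyanobenzyl, with a 1.1-fold lower number from compound 3 to compound 4 (0.05 log units; within the scatter) and a 1.2-fold lower number from compound 2 to compound 4 (0.06 log units; within the scatter) as the two readings. So in this assay the aromatic ring of the benzyl group is not needed to keep the number at this level, and 2-chlorobenzyl alone stands clear of cyclohexyl, with a 2.5-fold higher number from compound 1 to compound 4 (0.40 log units; beyond the scatter) leaving compound 1 with the lowest number of the four. No supporting data bear on why these groups read as they do.

Going by these compounds, it remains open whether the lower number of compound 1 follows the whole 2-chlorobenzyl group or the chlorine alone. Also open, on these data alone, is how a different kind of group on this nitrogen would read, such as an aminoethyl chain, a carboxylic acid or a plain butyl chain.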